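Ketone to alcohol on compound 2

The source may report more compounds than this note shows. Statements on the series, on what has been measured and on what is new or still open speak of the compounds shown alone.

In an ADME assay on L02 cells (Homo sapiens) for cytotoxicity, read by MTT assay, with a stated time of 48 h (a higher number here means a weaker inhibitor, a lower number a stronger inhibitor), compound 2 `CCn1c(C(=O)N(C)CC(=O)O)ccc1C(CC)(CC)c1ccc(OCC(=O)C(C)(C)C)c(C)c1` gives 8700 nM. Compound 1 `CCn1c(C(=O)NCCCN(C)C)ccc1C(CC)(CC)c1ccc(OCC(O)C(C)(C)C)c(C)c1` gives 470 nM. Compound 2 holds the higher of the two numbers, and the gap between the two compounds lies beyond the scatter. Compound 3 `CCn1c(C(=O)N(C)CC(=O)O)ccc1C(CC)(CC)c1ccc(OCC(O)C(C)(C)C)c(C)c1` carries 1-hydroxy-2,2-dimethylpropyl in place of (tert-butyl)carbonyl on a saturated chain carbon bound to an oxygen on an aromatic ring. Going by the values given here, compound 1 carries the same 1-hydroxy-2,2-dimethylpropyl but also differs elsewhere, so no measured step isolates this change. The expected step of a 1.2-fold lower number from compound 2 to compound 3 (0.09 log units; within the scatter) in this assay stays within the scatter. Compound 3 is estimated at 7000 nM with an expected range of 2500 nM to 20000 nM overall.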

Compound 3, half-maximal inhibitory concentration: 32600 nM
For compound 3 the middle estimate is 4.7-fold (0.67 log units) below the measured one; measured number outside the range, above it.
By their numbers in this assay, from the lowest: compound 1; then compound 2; then compound 3.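

In this assay, going by these compounds alone, 1-hydroxy-2,2-dimethylpropyl in place of (tert-butyl)carbonyl on a saturated chain carbon bound to an oxygen on an aromatic ring gives a 3.7-fold higher number from compound 2 to compound 3 (0.57 log units; beyond the scatter), the first reading of this change on its own. With that group held constant, (carboxymethyl)(methyl)amino in place of (3-(dimethylamino)propyl)amino on a carbonyl carbon gives a larger step, a 69-fold higher number from compound 1 to compound 3 (1.84 log units; beyond the scatter), and this separates the two changes that compound 1 and compound 2 mixed. Nothing at hand explains either step.

Still open, from the compounds shown here alone, is whether the alcohol step holds with (3-(dimethylamino)propyl)amino on the carbonyl carbon. Also open, going by these compounds, is how a methyl ester in place of the carboxylic acid, or a longer chain carrying the dimethylamino group, would read.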